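The source may report more compounds than this note shows. Statements on the series, on what has been measured and on what is new or still open speak of the compounds shown alone.

Measured so far:
compound 1, `CCn1ncnc1-c1ccccc1NCC1=NCCN1` — 94%
compound 2, `CCn1cccc1-c1ccccc1NCC1=NCCN1` — 0%
compound 3, `c1ccc(-c2nc[nH]n2)c(NCC2=NCCN2)c1` — 100%

In a functional assay with Alpha-1B adrenergic receptor (Homo sapiens) as the target, read by calcium flux (a lower number here means a smaller maximal response, a higher number a larger maximal response), compound 3 gives 100%, the highest of the three numbers. Among the compounds with values here, compound 1 sits nearest, with a reading that lies within the usual scatter of the one for compound 3, so no order between those two can be stated. Compound 2 lies furthest away: its value of 0% stands far beyond the scatter below compound 3.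

The next compound, compound 4, has the structure `Cn1ncnc1-c1ccccc1NCC1=NCCN1`. Against compound 3 the change is 1-methyl-1H-1,2,4-triazol-5-yl in place of 1H-1,2,4-triazol-3-yl on an aromatic carbon. Within the data shown here, no measured pair isolates this change, so the expected size of the step rests on the values at hand. Compound 1, whose structure stands beside its value, carries a group of the same ring type and gives 94%, within the scatter of compound 3. On that basis no step beyond the scatter is expected in this assay, in either direction. The step expected is a number 5 percentage points lower from compound 3 to compound 4 (within the scatter). Compound 4 is therefore estimated at 95%, in the range 80% to 105%.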

Compound 4, largest response reached (reported as maximal response), in percent of the reference or control that the assay uses: 93%
Compound 4: middle estimate off by 2 percentage points, on the high side; the measured number falls inside the stated range.
By their numbers in this assay, from the lowest: compound 2; then compounds 4, 1 and 3 (each within the scatter of the next).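

Position notes: in this assay, replacing 1H-1,2,4-triazol-3-yl with 1-methyl-1H-1,2,4-triazol-5-yl on the aromatic carbon gives a step that stays within the scatter (a number 7 percentage points lower from compound 3 to compound 4 (within the scatter)). The maximal response therefore holds up across this exchange, even though the entering group has no hydrogen-bond donor and the leaving group has one. The ethyl and methyl groups on the triazole nitrogen also cannot be told apart (a number 1 percentage points lower from compound 1 to compound 4 (within the scatter)), so the size of this small substituent shows no effect over these two compounds.

From the compounds shown here alone, it remains open whether a propyl group or longer chain on that nitrogen, or an amine in its place, would keep the response within the scatter. Also open, going by these compounds, is whether a methyl group would change the reading on the ring of compound 2, which gives 0%. No measurement available here bears on the reason for these results.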